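Bromo for tert-butyl on the aryl urea ring

The source may hold more compounds than are shown below. What is called first, only, known or untested is meant among the compounds shown, and "the series" means these compounds.

Compound 1 `C[C@@H](NC(=O)Nc1ccc(C(C)(C)C)cc1)c1ccccc1` is the reference point. For the measured compounds named here, in an ADME assay on the whole organism with Oryza sativa as the target, tested at 10 uM (a higher number here means a weaker effect of the compound at the concentration tested, a lower number a stronger effect), compound 1 gives 53%, the lowest of the three numbers known so far. Its configurational partner compound 2 `C[C@H](NC(=O)Nc1ccc(C(C)(C)C)cc1)c1ccccc1` gives 64%, a step of a number 11 percentage points higher from compound 1 to compound 2 (beyond the scatter); the only thing that separates the two is the fact that compounds 1 and 2 differ only in the configuration as drawn. Compound 3 `C[C@H](NC(=O)Nc1ccccc1Br)c1ccccc1`, which carries bromo on the urea ring in a different place and the other configuration, gives 102%; it differs from compound 1 in more than one respect, so its value alone is noted.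

Compound 4 `C[C@@H](NC(=O)Nc1ccc(Br)cc1)c1ccccc1` keeps the configuration of compound 1 and changes the substituent: bromo in place of tert-butyl on an aromatic carbon. Going by the values given here, no measured step isolates this change. The configuration step is modest, and compound 3 shows that a bromo-bearing analogue can reach the top of the range. The expectation for compound 4 in this assay is therefore a step of a number 19 percentage points higher from compound 1 to compound 4 (beyond the scatter), a weakening beyond the scatter but short of compound 3. The estimated value for compound 4 is 72%, within 48% to 96%.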

Compound 4, a percentage reported as activity, at one concentration (the size of the read-out at that concentration, not a potency): 87%
Compound 4: the middle estimate sits 15 percentage points below what was measured, within the range that was stated.
By their numbers in this assay, from the lowest: compound 1; then compound 2; then compound 4; then compound 3.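

In this assay, the substituent on this aromatic carbon proves to matter: with the configuration held as in compound 1, bromo in place of tert-butyl gives a number 34 percentage points higher from compound 1 to compound 4 (beyond the scatter). For the compounds shown here, this is the first step that isolates a substituent change, and it is large, whereas the configuration step is modest: a number 11 percentage points higher from compound 1 to compound 2 (beyond the scatter). Nothing available on these compounds speaks to why the swap of tert-butyl for bromo has this effect.

As far as these compounds go, whether an isopropyl or a methoxy group on the same aromatic carbon would land nearer compound 1 or compound 4 remains open, so two groups give no trend across substituents. Also open, from the compounds shown here alone, is whether bromo in place of tert-butyl in the configuration of compound 2 would give a step of similar size.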